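A mirror image set against a stability limit

The compounds below may be only part of what the source reports. "The series", "measured", "known", "first", "only" and "open" are said of these compounds alone.

In a physicochemical assay for metabolic stability, read by HPLC, in phosphate buffer, with a stated time of 12 h, at pH 6.8 (a higher number here means that the compound lasts longer, a lower number that the compound disappears faster), compound 1 `O=C(O)[C@@H](CO)NC(=O)[C@H]1C[C@@H](O)CN1` gives > 12 h, which is a limit of the assay and not a number. Compound 2 `O=C(O)[C@H](CO)NC(=O)[C@H]1C[C@@H](O)CN1` gives > 12 h, which is also a limit.

Compound 3 `O=C(O)[C@H](CO)NC(=O)[C@@H]1C[C@H](O)CN1` has not yet been measured. Its structure relates to that of compound 1 as follows: the two compounds have the same atoms and bonds and differ only in configuration as drawn: 3 of 3 stereo elements differ (all stereocentres are inverted: mirror images); a stereocentre at a saturated chain carbon is drawn R in compound 1 and S in compound 3; a stereocentre at a saturated ring carbon is drawn R in compound 1 and S in compound 3; a stereocentre at a saturated ring carbon is drawn R in compound 1 and S in compound 3. No group leaves or enters, and only the drawn configuration changes.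

Going by the values given here, the only measured step that bears on this is a step that the two limits leave unreadable from compound 1 to compound 2. It also changes configuration alone, as seen in the fact that compounds 1 and 2 differ only in the configuration as drawn, but one stereocentre differs there rather than all of them. Its size is hidden because of the limit of > 12 h in this assay, at which 2 of the 2 values shown sit, so the data give no measured size to carry over.

The expectation therefore rests on compound 2, whose value of > 12 h is a limit and gives no sign of a change. No shift beyond the usual scatter is expected in this assay, and the estimate is a step that the limit leaves unreadable from compound 1 to compound 3. The estimated half-life of compound 3 is 24 h, with an expected range from 12 h to 60 h, and the assay will most likely report only a limit again.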

Compound 3, half-life: > 12 h
Compound 3 was reported as a limit; the forecaster's own chance of this, stated with the estimate: 90%; the middle value lies beyond the limit too.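

Going by these compounds alone, no step among compound 1, compound 2 and compound 3 can be read in this assay because all three stop at a limit of the assay and not at a number: the limit of > 12 h in this assay, at which 3 of the 3 values shown sit. The compounds shown leave open how long each of the three actually lasts in this assay, and whether inverting one, two or all of the stereocentres changes that half-life at all.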